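This account rests on a few compounds, and the source may have more. Where it says the series, first, only, none or still open, it means among the compounds named here.

Within the data shown here, compound 1 `C/C(=N\NC(=O)c1cccc(S(=O)(=O)N2CCOCC2)c1)c1cccc(N)c1` is the first of the three measured compounds; in a functional assay on SMMC-7721 cells (Homo sapiens) for antiproliferative activity, read by MTT assay, with a stated time of 72 h (a lower number here means a stronger inhibitor, a higher number a weaker inhibitor), compound 1 gives > 100000 nM, which is a limit of the assay and not a number.
Compound 2 `C/C(=N\NC(=O)c1cccc(S(=O)(=O)N2CCOCC2)c1)c1cccc(O)c1` follows; in this assay compound 2 gives > 100000 nM, again a limit.
Compound 3 `C/C(=N\NC(=O)c1cccc(S(=O)(=O)N2CCOCC2)c1)c1cc(O)ccc1O` closes the set; in this assay compound 3 gives > 100000 nM, also a limit.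

Compound 3 therefore stands nowhere on a scale of numbers: only a limit is known for it, and the two further values around it are limits as well. The three steps among the measured compounds, a step that the two limits leave unreadable from compound 1 to compound 2, a step that the two limits leave unreadable from compound 1 to compound 3 and a step that the two limits leave unreadable from compound 2 to compound 3, cannot be read in size, as all three values sit at the limit of > 100000 nM in this assay, at which 3 of the 3 values shown sit.

The unmeasured compound 4 `C/C(=N\NC(=O)c1cccc(S(=O)(=O)N2CCOCC2)c1)c1cccc(N)c1O` differs from compound 3 in one place: 3-amino-2-hydroxyphenyl in place of 2,5-dihydroxyphenyl on a carbon with a double bond to nitrogen. Among the measured compounds shown here, none of the measured steps touches this pairing of groups, and none of them yields a readable size. The evidence on hand gives no ground to expect compound 4 to move clear of the limit at which compound 3 sits, so the step that the limit leaves unreadable from compound 3 to compound 4 is expected to stay within the scatter. For compound 4 in this assay the estimate is 150000 nM, within the range 40000 nM to 600000 nM, most likely reported again only as a limit.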

Compound 4, half-maximal inhibitory concentration: 2330 nM
The estimate for compound 4 lay 64-fold (1.81 log units) above the measured number; the whole stated range lies above it.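

In this assay, the aryl group on a carbon with a double bond to nitrogen proved able to bring this series to a readable number, which none of the earlier compounds had shown: 3-amino-2-hydroxyphenyl in place of 2,5-dihydroxyphenyl gives an at least 42-fold lower number from compound 3 to compound 4 (1.63 log units; beyond the scatter). The amino and hydroxy groups count here only as a pair, as far as these compounds go: hydroxy in place of hydrogen on an aromatic carbon gives an at least 42-fold lower number from compound 1 to compound 4 (1.63 log units; beyond the scatter), and 3-amino-2-hydroxyphenyl in place of 3-hydroxyphenyl gives an at least 42-fold lower number from compound 2 to compound 4 (1.63 log units; beyond the scatter), while 3-aminophenyl, 3-hydroxyphenyl and 2,5-dihydroxyphenyl all stay at the limit. All three steps are therefore minimum sizes, each starting from a limit and not from a number: the limit of > 100000 nM in this assay, at which 3 of the 4 values shown sit.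

The compounds shown leave open whether the amino group of compound 4 could give way to a methylamino or acetamido group, or its hydroxy group to a methoxy group or a fluorine, with the number kept. They also leave open whether the morpholine sulfonyl part of the shared core contributes to this activity, since it is the same in all four compounds.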